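Esters at the ring hydroxyl of a triterpenoid series

A few compounds are considered here, and "the series" means these few. Any claim that something is new, unique, unknown or untested is made for them only; others in the source may bear on it.

Compound 1 `CC1=CCC2C(CC[C@@]2(C)O)C(C)(C)C1CC[C@@H]1[C@@]2(C)CC[C@@H](O)C(C)(C)O[C@@H]2CC[C@]1(C)O` carries a free hydroxyl on its core and gives 44500 nM in a functional assay on MCF7 cells (Homo sapiens) for antiproliferative activity, read by MTT assay, with a stated time of 72 h; on this read-out lower numbers stand for stronger inhibition and higher numbers for weaker inhibition. Compound 2 `CC1=CC[C@H]2[C@H](CC[C@]2(C)O)C(C)(C)[C@@H]1CC[C@H]1[C@]2(C)CC[C@H](OC(=O)c3ccccc3)C(C)(C)O[C@H]2CC[C@@]1(C)O` is the benzoyl ester at that position and gives 21000 nM in this assay, the lowest of the three numbers shown, beyond the scatter from compound 1 but within the scatter of compound 3. Compound 3 `CC1=CC[C@H]2[C@H](CC[C@]2(C)O)C(C)(C)[C@@H]1CC[C@H]1[C@]2(C)CC/C(=N/OC(=O)c3ccccc3)C(C)(C)O[C@H]2CC[C@@]1(C)O`, the benzoyl oxime ester, gives 25600 nM in this assay; no ordering between compound 2 and compound 3 can be read from these two values.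

Compound 4 `CC1=CC[C@H]2[C@H](CC[C@]2(C)O)C(C)(C)[C@@H]1CC[C@H]1[C@]2(C)CC[C@H](OC(=O)c3ccc([N+](=O)[O-])o3)C(C)(C)O[C@H]2CC[C@@]1(C)O` is not yet measured. It differs from compound 2 in one place: 5-nitrofuran-2-yl in place of phenyl on a carbonyl carbon. Within the data shown here, no step between measured compounds addresses an aryl exchange on this ester, so the expectation rests on the narrow spread of the three numbers. The step from compound 2 to compound 4 is expected to be small, a 1.2-fold lower number from compound 2 to compound 4 (0.07 log units; within the scatter), likely within the scatter and with no firm direction. Compound 4 is therefore estimated at 18000 nM in this assay, within a range of 7000 nM to 45000 nM.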

Compound 4, half-maximal inhibitory concentration: 21300 nM
The estimate for compound 4 lay 1.2-fold (0.07 log units) below the measured number, and the stated range covers the measured number.
By their numbers in this assay, from the lowest: compounds 2, 4, 3 and 1 (each within the scatter of the next, the first and the last beyond it).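

On the ester at the ring hydroxyl, 5-nitrofuran-2-yl in place of phenyl on a carbonyl carbon gives a 1.0-fold higher number from compound 2 to compound 4 (0.01 log units; within the scatter) in this assay, the only aryl exchange at this position among the compounds shown. Benzoyl and (5-nitrofuran-2-yl)carbonyl differ in ring size, heavy atoms and hydrogen-bond acceptors, yet their numbers lie within the scatter, so this exchange separates the two esters by nothing that can be read here. No measurement shown bears on why the two esters read alike.

Open, going by these compounds, is whether a plain phenyl ring carrying a nitro group, or a furan-2-yl without one, would read like these two esters. Also open, on these data alone, is whether an acetyl ester or an ester with a longer chain ending in an amine at this position would fall outside this narrow band.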